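Swapping a Nitro for a Methoxy on the Urea Arm

The compounds below may be only part of what the source reports. "The series", "measured", "known", "first", "only" and "open" are said of these compounds alone.

Compound 2 `Cc1ccc(-c2ccsc2S(=O)(=O)NCCNC(=O)Nc2cccc([N+](=O)[O-])c2)c(Oc2ccc(O)c(O)c2)c1` is one of three compounds tested in a functional assay on RS4-11 cells (Homo sapiens) for inhibition, read by CCK-8 assay, with a stated time of 48 h; a higher number here means a weaker inhibitor, a lower number a stronger inhibitor. Compound 2 gives 9100 nM. Compound 3 `O=S(=O)(NCCNC(=S)Nc1cc(C(F)(F)F)cc(C(F)(F)F)c1)c1cc(-c2ccccc2Oc2ccc(O)c(O)c2)cs1` gives 4500 nM, so compound 2 stands as the higher, weaker, of the two numbers, with a gap beyond the scatter. Compound 1 `O=S(=O)(NCCNC(=S)Nc1cc(C(F)(F)F)cc(C(F)(F)F)c1)c1ccc(-c2ccccc2OCc2ccccc2)s1` reaches only the limit > 50000 nM and reports no number. Compound 4 `COc1ccc(NC(=O)NCCNS(=O)(=O)c2sccc2-c2ccc(C)cc2Oc2ccc(O)c(O)c2)cc1` keeps the whole of compound 2 except one group: 4-methoxyphenyl in place of 3-nitrophenyl on an amide-type nitrogen. Among the compounds with values here, no measured pair shows the effect of this exchange, so the step is expected to be small, in either direction or none beyond the scatter, namely a 1.1-fold lower number from compound 2 to compound 4 (0.06 log units; within the scatter). Compound 4 is therefore estimated at 8000 nM, with a range from 2500 nM to 25000 nM.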

Compound 4, half-maximal inhibitory concentration: 8200 nM
Beside the measured number, compound 4's estimate is 1.0-fold (0.01 log units) below it, within the range that was stated.
By their numbers in this assay, from the lowest: compounds 3, 4 and 2 (each within the scatter of the next, the first and the last beyond it). At a limit, above all of these: compound 1.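

In this assay, within the data shown here, the exchange of 3-nitrophenyl for 4-methoxyphenyl on the amide-type nitrogen gives the first direct reading at this position: a 1.1-fold lower number from compound 2 to compound 4 (0.05 log units; within the scatter). The aromatic ring at this position can therefore carry either of these two groups without a difference this assay can resolve. No measurement shown offers a reason for this result. Going by these compounds, whether a carboxylic acid or an amine on this ring, or a longer chain between the ring and the nitrogen, would shift the number remains open.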